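Working notes: chloro in place of cyclopropylmethoxy

The compounds below may be only part of what the source reports. "The series", "measured", "known", "first", "only" and "open" are said of these compounds alone.

Compound 3 `O=C(O)CCn1c(=O)oc2cc(OCC3CC3)c(Cl)cc21` stands second highest of the three numbers in a physicochemical assay for lipophilicity, read by HPLC, at pH 7.4 (on this read-out higher numbers stand for higher lipophilicity and lower numbers for lower lipophilicity), where compound 3 gives 2.09. Its nearest neighbour is compound 2 `CCOc1cc2oc(=O)n(CCC(=O)O)c2cc1Cl`, which in this assay gives 1.49; the step is a number 0.60 log units higher from compound 2 to compound 3 (beyond the scatter). The furthest is compound 1 `CC(C)Cc1cc2oc(=O)n(CCC(=O)O)c2cc1Cl`, which in this assay gives 3.03; the steps are a number 0.94 log units lower from compound 1 to compound 3 (beyond the scatter) and a number 1.54 log units lower from compound 1 to compound 2 (beyond the scatter).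

Compound 4 `O=C(O)CCn1c(=O)oc2cc(Cl)c(Cl)cc21` differs from compound 3 in one place: chloro in place of cyclopropylmethoxy on an aromatic carbon.

Going by the values given here, no measured step exchanges an alkoxy group for chloro, so the measured steps bear only indirectly. The steps that remove or reshape the cyclopropylmethoxy group, a number 0.94 log units lower from compound 1 to compound 3 (beyond the scatter) and a number 0.60 log units higher from compound 2 to compound 3 (beyond the scatter), were modest in size, and both went with the loss or gain of carbon on that chain. Removing the whole cyclopropylmethoxy group and leaving a single chloro is therefore expected to give a modest step downward in this assay, or none beyond the scatter.

Compound 4 is expected to give 1.85 in this assay, with a range from 1.4 to 2.4. The estimated step is a number 0.24 log units lower from compound 3 to compound 4 (within the scatter).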

Compound 4, distribution coefficient: 1.61
Beside the measured number, compound 4's estimate is 0.24 log units above it; measured number inside the range.
By their numbers in this assay, from the lowest: compounds 2 and 4 (each within the scatter of the next); then compound 3; then compound 1.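

In this assay, chloro and ethoxy on this aromatic carbon cannot be told apart, with a number 0.12 log units higher from compound 2 to compound 4 (within the scatter) and no separation between the two groups on this read-out. Chloro in place of cyclopropylmethoxy gives a number 0.48 log units lower from compound 3 to compound 4 (beyond the scatter) and chloro in place of isobutyl gives a number 1.42 log units lower from compound 1 to compound 4 (beyond the scatter) and so, among the four groups now seen at this position, isobutyl stands apart from all the others, while cyclopropylmethoxy stands apart from both chloro and ethoxy. No measurement is at hand that gives a reason for any of these steps.

Going by these compounds, how an amine, a nitrile or a longer alkoxy chain on this aromatic carbon would fall in this assay remains open, and so does the place of a group without a chain, such as fluoro. On these data alone, all four compounds also keep the other chloro group and the carboxylic acid, so it is equally open whether these steps would hold with a methyl group in place of that chloro or with a primary amide in place of the acid.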